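The source may hold more compounds than are shown below. What is called first, only, known or untested is meant among the compounds shown, and "the series" means these compounds.

Compounds measured in a toxicity assay on THP-1 cells (Homo sapiens) for inhibition; a higher number here means that more compound is tolerated, a lower number that less compound is tolerated:
compound 1 `Cn1c(-c2ccc(C#N)cc2)cnc1NC(=O)c1ncc[nH]1` gives > 100000 nM, a limit of the assay rather than a number.
Compound 2 `Cn1c(-c2ccc(C#N)cc2)cnc1NC(=O)c1ccc(F)cc1` gives > 50000 nM, again a limit.
Compound 3 `COc1ccc(CNC(=O)NC(=O)c2ccc(F)cc2)cc1` gives > 50000 nM, also a limit.

Compound 2 thus sits at the limit of > 50000 nM in this assay, at which 2 of the 3 values shown sit. Compound 1 sits at the limit of > 100000 nM in this assay, at which 1 of the 3 values shown sits. For the measured compounds named here, the only measured step, a step that the two limits leave unreadable from compound 1 to compound 2, is unreadable because both ends are limits. Compound 4 `Cn1c(-c2ccc(Cl)cc2)cnc1NC(=O)c1ccc(F)cc1` differs from compound 2 by chloro in place of cyano on an aromatic carbon. Going by the values given here, no measured step touches this change, so nothing supports expecting a step beyond the usual scatter in this assay. Compound 4 is therefore expected to show 80000 nM, with a range from 30000 nM to 200000 nM. The expected step is a step that the limit leaves unreadable from compound 2 to compound 4, most likely reported only as a limit.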

Compound 4, half-maximal cytotoxic concentration: 37000 nM
Compound 4: middle estimate off by 2.2-fold (0.33 log units), on the high side; measured number inside the range.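

In this assay, for the compounds shown here, compound 4 gives 37000 nM, the first real number here rather than a limit, so the 4-chlorophenyl version brings this series into the range the assay can read. Replacing the nitrile with chloro gives an at least 1.3-fold lower number from compound 2 to compound 4 (0.13 log units; that floor lies within the scatter). This is only a floor, because the value of compound 2 is a limit: the limit of > 50000 nM in this assay, at which 2 of the 4 values shown sit.

From the compounds shown here alone, the true size of the step stays open, since compound 2 has no exact number. Also open, going by these compounds, is how an amine or a carboxylic acid at this place on the ring would fare.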